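This account rests on a few compounds, and the source may have more. Where it says the series, first, only, none or still open, it means among the compounds named here.

Working notes on the urea series in an ADME assay on the whole organism with Oryza sativa as the target, tested at 10 uM; on this read-out higher numbers stand for a weaker effect at the one concentration tested and lower numbers for a stronger effect. Compound 1 `CCc1ccccc1NC(=O)N[C@H](C)c1ccccc1` gives 92%. Compound 2 `CCCCc1ccc(NC(=O)N[C@H](C)c2ccccc2)cc1` gives 28%, the lowest of the three numbers in hand. Compound 3 `CCCCc1ccc(NC(=O)N[C@@H](C)c2ccccc2)cc1` gives 60%. For the measured compounds named here, the only single-point step among the measured compounds is a number 32 percentage points higher from compound 2 to compound 3 (beyond the scatter), a step that rests on the fact that compounds 2 and 3 differ only in the configuration as drawn alone, as the stereocentre at the saturated chain carbon is the sole point of difference. Going by the values given here, none of the measured steps changes the group on the aromatic ring.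

Compound 4 `CC(=O)c1ccc(NC(=O)N[C@H](C)c2ccccc2)cc1` has not yet been run in this assay. Against compound 2 the change is acetyl in place of butyl on an aromatic carbon. Among the compounds with values here, no measured step bears on this change, since the one step in hand concerns configuration only; the ring substituent differs between compound 1 and compound 2 as well, where compound 1 gives 92% and compound 2 gives 28%, but this pair differs in more than one place. An upward step, a number 32 percentage points higher from compound 2 to compound 4 (beyond the scatter), is expected, yet with wide uncertainty. Compound 4 is estimated at 60%, within 30% to 90%.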

Compound 4, a percentage reported as activity, at one concentration (the size of the read-out at that concentration, not a potency): 84%
For compound 4 the middle estimate is 24 percentage points below the measured one; low and high end bracket the measured number.
By their numbers in this assay, from the lowest: compound 2; then compound 3; then compounds 4 and 1 (each within the scatter of the next).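

Working notes: in this assay, acetyl in place of butyl on an aromatic carbon, para to a large group, gives a number 56 percentage points higher from compound 2 to compound 4 (beyond the scatter). For the compounds shown here, until now, the only one-place step concerned configuration at the saturated chain carbon; this step shows that, with that configuration held as drawn in compound 2, the group at this ring position also shifts the read-out, and here the exchange goes with a weaker effect at the one concentration tested. Nothing in hand accounts for the size or direction of this step.

Open, from the compounds shown here alone, is whether a shorter alkyl chain, a longer chain, or a methoxy group at the same ring position would stay near compound 2 or near compound 4. Also open, going by these compounds, is whether the acetyl compound drawn with the opposite configuration would shift in the same direction as compound 3 does from compound 2.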